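The source may hold more compounds than are shown below. What is called first, only, known or untested is meant among the compounds shown, and "the series" means these compounds.

Working notes on the series

Two members of the series have been run in a physicochemical assay for solubility, with a stated time of 18 h, at pH 7.4; a higher number here means a more soluble compound, a lower number a less soluble compound. Compound 1 `COc1ccccc1Oc1ccc2c(NCCCNCc3ccco3)ccnc2c1` gives 14500 nM in this assay. For the measured compounds named here, compound 2 `c1coc(CNCCCNc2ccnc3cc(CC4CCCCC4)ccc23)c1` gives 4200 nM in this assay, and a 3.5-fold lower number from compound 1 to compound 2 (0.54 log units; beyond the scatter) is the only step so far. On those two numbers compound 2 stands at the lower end, with compound 1 the nearest and higher by that step.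

Compound 3 `c1coc(CNCCCNc2ccnc3cc(-c4cccc5ccccc45)ccc23)c1` is the next member. It differs from compound 2 in one place: naphthalen-1-yl in place of cyclohexylmethyl on an aromatic carbon. Going by the values given here, no measured step bears directly on this exchange, since the one step in hand swapped 2-methoxyphenoxy for cyclohexylmethyl at the same position and only shows that this position can move the number by a modest amount. With nothing closer to lean on, the expectation for compound 3 is a modest step downward from compound 2, as a 2.1-fold lower number from compound 2 to compound 3 (0.32 log units; beyond the scatter), which is expected to leave compound 3 near 2000 nM in this assay. The expected range for compound 3 runs from 600 nM to 8000 nM.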

Compound 3, solubility: 32000 nM
Compound 3: middle estimate off by 16-fold (1.20 log units), on the low side, and the stated range ends below it.
By their numbers in this assay, from the lowest: compound 2; then compound 1; then compound 3.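

In this assay, for the compounds shown here, this position, on an aromatic carbon meta to a fused ring and para to a fused ring, can move the number upward as well as downward: a 7.6-fold higher number from compound 2 to compound 3 (0.88 log units; beyond the scatter) is the largest step at this position so far, and it runs opposite to a 3.5-fold lower number from compound 1 to compound 2 (0.54 log units; beyond the scatter). Naphthalen-1-yl also stands higher than 2-methoxyphenoxy, with a 2.2-fold higher number from compound 1 to compound 3 (0.34 log units; beyond the scatter), so among these three compounds a group of two six-membered aromatic rings of carbon only, with 0 hydrogen-bond donors and 0 hydrogen-bond acceptors, carries the highest number. Nothing available accounts for this rise in the number.

The compounds shown leave open whether the change follows the aromatic rings themselves or the loss of the carbon link in cyclohexylmethyl, a question that phenyl, benzyl and cyclohexyl at the same position would separate. They also leave open how a carboxylic acid or an amine at this position would compare with naphthalen-1-yl, and whether the order of these three groups holds on a different side chain.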